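Dimethylamino for acetyl on the pendant phenyl ring

This account rests on a few compounds, and the source may have more. Where it says the series, first, only, none or still open, it means among the compounds named here.

Compound 1 `COc1cc(C)cc(-c2c(-c3ccnc(-c4ccc(C(C)=O)cc4)c3)cnn2CC#N)c1` was run in a functional assay on CCRF-CEM cells (Homo sapiens) for inhibition, read by sulforhodamine B assay, with a stated time of 48 h; on this read-out lower numbers stand for stronger inhibition of growth and higher numbers for weaker inhibition of growth. In this assay compound 1 gives only the limit > 100000 nM, not a number. Compound 2 `Cc1cc(O)cc(-c2nn(CC#N)cc2-c2ccnc(-c3ccc(Oc4ccccc4)cc3)c2)c1` likewise stops at the limit > 100000 nM in this assay. Compound 3 `COc1cc(C)cc(-c2nn(CC#N)cc2-c2ccnc(-c3ccc(N(C)C)cc3)c2)c1` also reaches only the limit > 100000 nM. Compound 1 therefore stands nowhere distinct: the limit of > 100000 nM in this assay, at which 3 of the 3 values shown sit, so the three cannot be ordered. Compound 4 `COc1cc(C)cc(-c2c(-c3ccnc(-c4ccc(N(C)C)cc4)c3)cnn2CC#N)c1` differs from compound 1 by dimethylamino in place of acetyl on an aromatic carbon. Among the measured compounds shown here, no measured step carries this change. Compound 3 already carries dimethylamino on its phenyl and sits at its limit > 100000 nM. The expected step is a number no higher from compound 1 to compound 4 (the limit leaves the size open), nothing beyond the scatter, and compound 4 is expected to give 100000 nM (range 40000 nM to 300000 nM), most likely again only a limit.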

Compound 4, concentration for total growth inhibition: > 100000 nM
Compound 4: no number, only a limit (the forecaster's own chance of this, stated with the estimate: 85%); the middle value sits exactly at the limit.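

Compound 1 and compound 4 both give only a limit, not a number, in this assay, so no step can be read between them: the limit of > 100000 nM in this assay, at which 4 of the 4 values shown sit.

Whether dimethylamino in place of acetyl changes growth inhibition at all, and how the compounds shown would rank, stays open.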